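Trimming methoxy groups on a cinnamamide-linked benzophenone

The source may report more compounds than this note shows. Statements on the series, on what has been measured and on what is new or still open speak of the compounds shown alone.

Compound 1 `COc1ccc(C(=O)c2cc(OC)c(OC)c(OC)c2)cc1N` gives 30 nM.
Compound 2 `COc1cccc(/C=C/C(=O)Nc2cc(OC)c(OC)c(OC)c2)c1` gives 8500 nM.
Compound 3 `COc1ccc(C(=O)c2cc(OC)c(OC)c(OC)c2)cc1NC(=O)/C=C/c1cc(OC)c(OC)c(OC)c1` gives 1200 nM.

All three numbers come from a functional assay on B16 cells (Mus musculus) for cytotoxicity, read by MTT assay, with a stated time of 72 h; on this read-out higher numbers stand for weaker inhibition and lower numbers for stronger inhibition. Among them, compound 3 holds the second highest number: compound 2 sits above it, beyond the usual scatter, while compound 1 sits far below it, also beyond the scatter. Compound 3 joins the benzophenone of compound 1 to a cinnamamide arm carrying a second trimethoxyphenyl group, and the measured number is much weaker than that of compound 1 alone.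

Compound 4 `COc1ccc(/C=C/C(=O)Nc2cc(C(=O)c3cc(OC)c(OC)c(OC)c3)ccc2OC)cc1` has not yet been measured. It differs from compound 3 in one place: 4-methoxyphenyl in place of 3,4,5-trimethoxyphenyl on a double-bonded chain carbon bound to a double-bonded chain carbon. Among the compounds with values here, no measured pair in this set shows this particular swap, so the size of the step is uncertain. Given that compound 2, whose cinnamamide also carries a single methoxy group, gives 8500 nM, a modest weakening is expected, a step of a 1.5-fold higher number from compound 3 to compound 4 (0.18 log units; within the scatter). For compound 4 the estimate is 1800 nM, within a range of 500 nM to 7000 nM.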

Compound 4, half-maximal inhibitory concentration: 8700 nM
Compound 4: middle estimate off by 4.8-fold (0.68 log units), on the low side, outside the stated range (above it).
By their numbers in this assay, from the lowest: compound 1; then compound 3; then compounds 2 and 4 (each within the scatter of the next).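

In this assay, the swap of 3,4,5-trimethoxyphenyl for 4-methoxyphenyl on a double-bonded chain carbon bound to a double-bonded chain carbon gives a 7.3-fold higher number from compound 3 to compound 4 (0.86 log units; beyond the scatter), a step beyond the usual scatter. Within the data shown here, this pair is the first in the set to change the aromatic ring of the cinnamamide arm while leaving everything else the same, and it shows that compound 3 loses clear ground in this assay when that ring keeps only a single methoxy group. Nothing measured here explains the size of this step.

A single pair cannot show whether the loss follows from the number of methoxy groups or from which ones remain. A 3,4-dimethoxyphenyl, a 4-hydroxyphenyl or a 4-aminophenyl group at this place would help separate those possibilities.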